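The source may hold more compounds than are shown below. What is called first, only, known or untested is meant among the compounds shown, and "the series" means these compounds.

In a functional assay on HCT-116 cells (Homo sapiens) for inhibition, read by MTT assay, with a stated time of 72 h (on this read-out lower numbers stand for stronger inhibition and higher numbers for weaker inhibition), three compounds have been measured. Compound 1 `Nc1ncnc2c1c(-c1cnc3[nH]ccc3c1)nn2CCCC(=O)NO` gives only a limit, > 150000 nM, not a number. Compound 2 `Nc1nc2cc(-c3nn(CCCCCCCCCC(=O)NO)c4ncnc(N)c34)ccc2o1` gives 23100 nM. Compound 3 `Nc1nc2cc(-c3nn(CC(=O)NO)c4ncnc(N)c34)ccc2o1` gives 11400 nM, the lowest of the two numbers; compound 2 sits a step higher that lies beyond the usual scatter. Compound 4 `Nc1nc2cc(-c3nn(CCCCC(=O)NO)c4ncnc(N)c34)ccc2o1` has not yet been measured. It differs from compound 3 in one place: 3-(hydroxycarbamoyl)propyl in place of hydroxycarbamoyl on a saturated chain carbon bound to an aromatic nitrogen. Going by the values given here, no measured pair shows this same change. Compound 4 carries a chain longer than that of compound 3 and shorter than that of compound 2, and those two compounds differ by only a modest step. A small step in either direction, or none beyond the scatter, is therefore expected: a 1.4-fold lower number from compound 3 to compound 4 (0.15 log units; within the scatter). Compound 4 is estimated at 8000 nM, within a range from 3000 nM to 30000 nM.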

Compound 4, half-maximal inhibitory concentration: 34000 nM
The estimate for compound 4 lay 4.3-fold (0.63 log units) below the measured number; the whole stated range lies below it.
By their numbers in this assay, from the lowest: compound 3; then compounds 2 and 4 (each within the scatter of the next). At a limit, above all of these: compound 1.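

Replacing hydroxycarbamoyl with 3-(hydroxycarbamoyl)propyl at this position gives a 3.0-fold higher number from compound 3 to compound 4 (0.47 log units; beyond the scatter) and shows that the chain length here can shift the read-out. The remaining step, a 1.5-fold higher number from compound 2 to compound 4 (0.17 log units; within the scatter), leaves those two longer chains unresolved, so only the shortest chain of compound 3 stands apart and the numbers do not track chain length steadily. Nothing measured here explains this step. Still open, going by these compounds, is how a carboxylic acid or a primary amide in place of the hydroxycarbamoyl end would read on this chain. A hexyl chain ending in hydroxycarbamoyl would also help to show how the numbers run at lengths not covered here.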